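Swapping the sulfonyl aryl group in a chromenone series

The source may report more compounds than this note shows. Statements on the series, on what has been measured and on what is new or still open speak of the compounds shown alone.

Compound 1 `C=CCNC(=O)n1c(-c2ccc(OC)cc2)cc(=O)c2c(OC)cc(OC)cc21`: 12000 nM
Compound 2 `COc1ccc(-c2cc(=O)c3c(OC)cc(OC)cc3n2S(=O)(=O)c2ccc(F)cc2)cc1`: > 65500 nM
Compound 3 `COc1ccc(-c2cc(=O)c3c(OC)cc(OC)cc3n2S(=O)(=O)c2ccc(Cl)cc2)cc1`: > 34400 nM

Three compounds share one core and differ only in the group on the aromatic nitrogen. In a functional assay on KOPN-8 cells (Homo sapiens) for antiproliferative activity, with a stated time of 72 h (on this read-out lower numbers stand for an effect already at smaller amounts and higher numbers for an effect only at larger amounts of compound), compound 1 gives 12000 nM. Compound 2 reaches only a limit of the assay, > 65500 nM. Compound 3 likewise reaches only a limit, > 34400 nM. Both sulfonyl compounds thus sit at the far end of the numbers shown, as the limit of > 65500 nM in this assay, at which 1 of the 3 values shown sits, and the limit of > 34400 nM in this assay, at which 1 of the 3 values shown sits, tell; the steps of an at least 5.4-fold higher number from compound 1 to compound 2 (0.73 log units; beyond the scatter) and an at least 2.8-fold higher number from compound 1 to compound 3 (0.45 log units; beyond the scatter) are beyond the scatter, while a step that the two limits leave unreadable from compound 2 to compound 3.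

Compound 4 `COc1ccc(-c2cc(=O)c3c(OC)cc(OC)cc3n2S(=O)(=O)c2ccc(Br)s2)cc1` keeps the sulfonyl but changes the ring on it: 5-bromothiophen-2-yl in place of 4-chlorophenyl on a sulfonyl sulfur. For the measured compounds named here, no measured step covers a change of this kind, so the expectation rests on the two sulfonyl compounds both ending at a limit. Compound 4 is expected to stand near 40000 nM, between 10000 nM and 120000 nM. For compound 4 this expectation means a step that the limit leaves unreadable from compound 3 to compound 4, most likely again reported only as a limit.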

Compound 4, half-maximal effective concentration: > 48200 nM
Compound 4 was reported as a limit; the forecaster's own chance of this, stated with the estimate: 70%; at least 1.2-fold (0.08 log units) between middle value and limit.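

Compound 4 again gives only a limit, so moving from a six-membered aromatic ring of carbon only to a five-membered aromatic ring with a hetero atom on the sulfonyl sulfur yields no readable value: the limit of > 48200 nM in this assay, at which 1 of the 4 values shown sits. Compared with the allylcarbamoyl group on the aromatic nitrogen, this sulfonyl group gives an at least 4.0-fold higher number from compound 1 to compound 4 (0.60 log units; beyond the scatter), so a third sulfonyl compound falls on the same side of compound 1 in this assay. The steps among compound 2, compound 3 and compound 4 cannot be read, for each joins two limits.

On these data alone, whether the ring on the sulfonyl sulfur matters at all therefore stays open. Also open, as far as these compounds go, is how a longer chain in place of allyl, or an amine on the carbamoyl group, would fare on the aromatic nitrogen.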